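A few compounds are considered here, and "the series" means these few. Any claim that something is new, unique, unknown or untested is made for them only; others in the source may bear on it.

Working notes on the amide-linked series. The reference here is compound 2 `COc1ccc2c(=O)c(/C=C/C(=O)NCc3ccccc3)coc2c1`. In a functional assay (QGY7701 cells, Homo sapiens) for inhibition, read by MTT assay, with a stated time of 48 h (on this read-out lower numbers stand for stronger inhibition and higher numbers for weaker inhibition), compound 2 gives > 100000 nM, which is a limit of the assay and not a number. Compound 3 `COc1ccc(NC(=O)/C=C/c2coc3cc(OC)ccc3c2=O)cc1` carries 4-methoxyphenyl in place of benzyl on an amide-type nitrogen. In this assay compound 3 gives > 100000 nM, again a limit. The step that the two limits leave unreadable from compound 2 to compound 3 thus cannot be read, the reason being (the limit of > 100000 nM in this assay, at which 2 of the 3 values shown sit). For the measured compounds named here, compound 1 `COc1ccc(CNC(=O)/C=C/c2coc3cc(O)ccc3c2=O)cc1` carries a different substituent on the shared core; in this assay compound 1 gives 10000 nM, the only value in the set that is a number rather than a limit.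

Compound 4 `COc1ccc(CNC(=O)/C=C/c2coc3cc(OC)ccc3c2=O)cc1` is to be measured in this assay. Relative to compound 2 the change is methoxy in place of hydrogen on an aromatic carbon. Going by the values given here, no measured step bears directly on this change: the step from compound 2 to compound 3 is unreadable, and compound 4 differs from compound 1 in a second place as well, so what compound 1 shows at 10000 nM carries over only loosely. For compound 4 the expected value in this assay is 60000 nM. The expected range for compound 4 runs from 10000 nM to 150000 nM. This estimate implies an expected step of an at least 1.6-fold lower number from compound 2 to compound 4 (0.22 log units; that floor lies within the scatter), counted from a limit value.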

Compound 4, half-maximal inhibitory concentration: 15700 nM
Beside the measured number, compound 4's estimate is 3.8-fold (0.58 log units) above it, within the range that was stated.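

In this assay, the change from benzyl to 4-methoxybenzyl gives the first readable result for methoxy at this place on the aromatic ring, para to a large group, with an at least 6.3-fold lower number from compound 2 to compound 4 (0.80 log units; beyond the scatter), and the one-carbon difference between the 4-methoxyphenyl and 4-methoxybenzyl amides also reads, with an at least 6.3-fold lower number from compound 3 to compound 4 (0.80 log units; beyond the scatter). On the other side of the molecule, methyl in place of hydrogen on the oxygen of the shared core gives a 1.6-fold higher number from compound 1 to compound 4 (0.20 log units; within the scatter), so this pair does not separate the two forms of that oxygen. The two steps that start from compound 2 and compound 3 give only minimum sizes because each is counted from a limit: the limit of > 100000 nM in this assay, at which 2 of the 4 values shown sit.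

With methoxy as the only group shown at this place, the compounds leave open whether an amine or a carboxylic acid there would give a similar step. They also leave open how a longer chain between the amide nitrogen and the 4-methoxyphenyl group would read in this assay.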